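Compound 3 to compound 4: benzoyl for (thiophen-2-yl)carbonyl

The compounds below may be only part of what the source reports. "The series", "measured", "known", "first", "only" and "open" are said of these compounds alone.

Compound 1 `COc1cc(-c2nnc3n2NC(c2cccs2)C(C(=O)c2ccc(F)cc2)S3)cc(OC)c1OC` gives 45000 nM in a functional assay on A549 cells (Homo sapiens) for cytotoxicity, read by MTT assay, with a stated time of 48 h; a higher number here means a weaker inhibitor, a lower number a stronger inhibitor. Compound 2 `COc1ccc(C(=O)C2Sc3nnc(-c4cc(OC)c(OC)c(OC)c4)n3NC2c2cccs2)cc1` is reported in this assay only as a limit, > 100000 nM. For the measured compounds named here, the single measured step, an at least 2.2-fold higher number from compound 1 to compound 2 (0.34 log units; beyond the scatter), rests on (the limit of > 100000 nM in this assay, at which 1 of the 3 values shown sits). Compound 3 `COc1cc(-c2nnc3n2NC(c2ccco2)C(C(=O)c2cccs2)S3)cc(OC)c1OC` gives 78700 nM in this assay; its number and that of compound 1 lie within the scatter of each other, so no order is read between them. Compound 4 `COc1cc(-c2nnc3n2NC(c2ccco2)C(C(=O)c2ccccc2)S3)cc(OC)c1OC` carries phenyl in place of thiophen-2-yl on a carbonyl carbon. Going by the values given here, no measured step bears on an aryl exchange at the carbonyl carbon, since the one step concerns methoxy in place of fluoro on an aromatic carbon. Compound 4 is therefore expected near compound 3, at 70000 nM within 30000 nM to 150000 nM, that is a 1.1-fold lower number from compound 3 to compound 4 (0.05 log units; within the scatter).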

Compound 4, half-maximal inhibitory concentration: 33400 nM
Compound 4: the middle estimate sits 2.1-fold (0.32 log units) above what was measured, and the stated range covers the measured number.
By their numbers in this assay, from the lowest: compounds 4, 1 and 3 (each within the scatter of the next, the first and the last beyond it). At a limit, above all of these: compound 2.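

Exchanging the aryl group on the carbonyl carbon gives, in this assay, a 2.4-fold lower number from compound 3 to compound 4 (0.37 log units; beyond the scatter). For the compounds shown here, the earlier step covered only methoxy in place of fluoro on an aromatic carbon, so this is the first sign that replacing the thiophen-2-yl ring itself with phenyl shifts the number, though only modestly. No measured property bears on the reason for this step. Open, from the compounds shown here alone, is whether a pyridin-2-yl or cyclohexyl group on the same carbonyl carbon would continue the shift, and whether the step holds with the rest of the molecule changed.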